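Ring fluorination and cytotoxicity across two cores

The source may hold more compounds than are shown below. What is called first, only, known or untested is meant among the compounds shown, and "the series" means these compounds.

Compound 2 `CCNCC1CCN(c2cc3c(cc2F)c(=O)c(C(=O)O)cn3CC)C1` and compound 1 `CCNCC1CCN(c2c(F)cc3c(=O)c(C(=O)O)cn(CC)c3c2F)C1` share one core and differ in a single place, (fluoro in place of hydrogen on an aromatic carbon). In a functional assay on V79 cells (Cricetulus griseus) for cytotoxicity, read by colony formation (a higher number here means a weaker inhibitor, a lower number a stronger inhibitor), compound 2 gives 310 ug/mL, and compound 1 gives 160 ug/mL; the step between them is a 1.9-fold lower number from compound 2 to compound 1 (0.29 log units; within the scatter), so the added fluoro leaves the read-out essentially unchanged in this pair.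

Compound 3 `NC1CCCN(c2cc3c(cc2F)c(=O)c(C(=O)O)cn3C2CC2)C1` rests on a second core with a different side chain; the difference between the two cores is not broken down here. In this assay compound 3 gives only a limit, > 500 ug/mL, and this is the limit of > 500 ug/mL in this assay, at which 1 of the 3 values shown sits.

Compound 4 `NC1CCCN(c2c(F)cc3c(=O)c(C(=O)O)cn(C4CC4)c3c2F)C1` differs from compound 3 by fluoro in place of hydrogen on an aromatic carbon. This is the same kind of change as that made between compound 2 and compound 1, though here the fluoro enters ortho to a 3-aminopiperidin-1-yl group rather than ortho to a 3-((ethylamino)methyl)pyrrolidin-1-yl group.

The expected step is an at least 1.2-fold lower number from compound 3 to compound 4 (0.09 log units; that floor lies within the scatter), which rests on a 1.9-fold lower number from compound 2 to compound 1 (0.29 log units; within the scatter), a step within the scatter. In this assay compound 4 is estimated at 400 ug/mL, with a likely range from 200 ug/mL to 800 ug/mL.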

Compound 4, half-maximal inhibitory concentration: 53 ug/mL
For compound 4 the middle estimate is 7.5-fold (0.88 log units) above the measured one, outside the stated range (below it).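

In this assay the fluoro in place of hydrogen on an aromatic carbon gives an at least 9.4-fold lower number from compound 3 to compound 4 (0.97 log units; beyond the scatter), so the size of this change does not carry over from one core to the other: the same change on two cores in this assay, a 1.9-fold lower number (0.29 log units; within the scatter) from compound 2 to compound 1 and an at least 9.4-fold lower number (0.97 log units; beyond the scatter) from compound 3 to compound 4, at least 4.8-fold (0.68 log units) apart, beyond the scatter of two such steps. The step is only a floor, since compound 3 stands at a limit of the assay and not at a number: the limit of > 500 ug/mL in this assay, at which 1 of the 4 values shown sits. The two pairs differ in both core and side chain, the 3-aminopiperidin-1-yl group in one and the 3-((ethylamino)methyl)pyrrolidin-1-yl group in the other, so these data do not show which of the two sets the gap, nor how large the step in the second pair really is.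

Open, going by these compounds, is whether the larger step follows the 3-aminopiperidin-1-yl group or the rest of the core of compound 3, which that group set on the core of compound 1 would help to separate. Also open, on these data alone, is whether chloro or a methoxy group in the same place gives a step of similar size.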